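The source may hold more compounds than are shown below. What is called first, only, known or untested is meant among the compounds shown, and "the series" means these compounds.

Measured compounds so far:
compound 1, `O=C(NCc1ccc(F)cc1)c1nc(NCCO)c2cccnc2c1O`: in a functional assay on MDA-MB-435 cells (Homo sapiens) for cytotoxicity, read by MTT assay, with a stated time of 72 h (a lower number here means a stronger inhibitor, a higher number a weaker inhibitor), compound 1 gives > 20000 nM, which is a limit of the assay and not a number.
compound 2, `N[C@H]1CC[C@H](Nc2c(C(=O)NCc3ccco3)nc(Br)c3cccnc23)CC1`: in this assay compound 2 gives > 10000 nM, likewise a limit.
compound 3, `O=C(NCc1ccc(F)cc1)c1nc(Br)c2cccnc2c1NCCCNc1c(C(=O)NCc2ccc(F)cc2)nc(Br)c2cccnc12`: in this assay compound 3 gives > 20000 nM, again a limit.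

For the measured compounds named here, none of the three compounds returns a number, so no step between measured compounds can be stated and nothing in the set can be ordered. Compound 2 stands at the limit of > 10000 nM in this assay, at which 1 of the 3 values shown sits, while the other two sit at the limit of > 20000 nM in this assay, at which 2 of the 3 values shown sit; the two limits show only that none of the three reaches measurable inhibition within the tested range.

Compound 4, `N[C@H]1CC[C@H](Nc2c(C(=O)NCc3ccccn3)nc(Br)c3cccnc23)CC1`, is the next member and has not yet been measured in this assay. It differs from compound 2 in one place: pyridin-2-yl in place of furan-2-yl on a saturated chain carbon bound to an amide-type nitrogen. Both rings carry one hetero atom and one hydrogen-bond acceptor, and the change sits on the saturated chain carbon bound to the amide-type nitrogen, away from the bromine and the aminocyclohexyl group that compound 4 keeps. Going by the values given here, with compound 2 at a limit and no measured step to lean on, no movement beyond the scatter is expected in either direction; the likeliest outcome is another limit.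

For compound 4 in this assay the expected value is estimated at 15000 nM, with a range from 5000 nM to 50000 nM. This estimate means an expected step that the limit leaves unreadable from compound 2 to compound 4, within the scatter.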

Compound 4, half-maximal inhibitory concentration: 4000 nM
Estimate against measurement, compound 4: 3.8-fold (0.57 log units) above, outside the stated range (below it).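

In this assay, for the compounds shown here, compound 4 gives 4000 nM, the only number in the set so far, which shows that a single change on the saturated chain carbon bound to the amide-type nitrogen can give this series a measurable value. Pyridin-2-yl in place of furan-2-yl there gives an at least 2.5-fold lower number from compound 2 to compound 4 (0.39 log units; beyond the scatter), although the two groups match in hydrogen-bond donors and acceptors and differ in ring size and in the hetero atom. This step has a floor and no measured size, as compound 2 stands at a limit of the assay: the limit of > 10000 nM in this assay, at which 1 of the 4 values shown sits.

With one pair, the ring size and the ring nitrogen cannot be told apart as the source of the step; phenyl or pyridin-4-yl on the same saturated chain carbon would separate them. As far as these compounds go, the share of the bromine and the aminocyclohexyl group in the value of compound 4 also stays open.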